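Ring size on the thiocarbonyl amine: piperidine to pyrrolidine

The source may report more compounds than this note shows. Statements on the series, on what has been measured and on what is new or still open speak of the compounds shown alone.

Compound 1 `Cc1cccc(/C(N)=N/NC(=S)N2CCSCC2)n1` and compound 2 `Cc1cccc(/C(N)=N/NC(=S)N2CCCCC2)n1` share one core and differ only in the ring attached to the thiocarbonyl carbon. In a functional assay on MCF7 cells (Homo sapiens) for cytotoxicity, read by MTT assay, with a stated time of 72 h, tested at 10 uM (on this read-out lower numbers stand for less inhibition of growth and higher numbers for more inhibition of growth at the one concentration tested), compound 1 gives 22.5%, and in the same assay compound 2 gives 39%. Going by the values given here, the one measured step, a number 16.5 percentage points higher from compound 1 to compound 2 (beyond the scatter), is the only comparison available so far. Compound 2 therefore stands highest of the two numbers, with compound 1 the nearest, lower by a step beyond the scatter.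

Compound 3 `Cc1cccc(/C(N)=N/NC(=S)N2CCCC2)n1` has not yet been measured. It differs from compound 2 as follows: pyrrolidin-1-yl in place of piperidin-1-yl on a thiocarbonyl carbon. Among the compounds with values here, only the step from compound 1 to compound 2 bears on this change, as it also alters the ring on the thiocarbonyl carbon; that step was modest and beyond the scatter, but it exchanged thiomorpholin-4-yl for piperidin-1-yl rather than a six-membered ring for a five-membered one, so it is a loose guide. Going from piperidin-1-yl to pyrrolidin-1-yl is expected to move the read-out little. For compound 3 a value near 35% is estimated in this assay, within 20% to 52%. The expected change is a number 4 percentage points lower from compound 2 to compound 3 (within the scatter), which would lie within the scatter.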

Compound 3, percent growth inhibition at one concentration: 38.2%
Beside the measured number, compound 3's estimate is 3.2 percentage points below it; low and high end bracket the measured number.
By their numbers in this assay, from the lowest: compound 1; then compounds 3 and 2 (each within the scatter of the next).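

In this assay, replacing piperidin-1-yl with pyrrolidin-1-yl on a thiocarbonyl carbon gives a number 0.8 percentage points lower from compound 2 to compound 3 (within the scatter), so at the one concentration tested this position accepts the five-membered ring without a change beyond the scatter. The thiomorpholin-4-yl ring of compound 1 remains the one that stands apart, with a number 15.7 percentage points higher from compound 1 to compound 3 (beyond the scatter) alongside the earlier a number 16.5 percentage points higher from compound 1 to compound 2 (beyond the scatter), and among these three compounds, the read-out does not track ring size alone. No measured property of these compounds is available to account for the separation of compound 1 from the other two.

On these data alone, it remains open whether a morpholin-4-yl ring, a 4-methylpiperazin-1-yl ring or an open-chain dimethylamino group on the thiocarbonyl carbon would fall with compound 1 or with compound 2 and compound 3. Single-concentration numbers also leave open whether compound 2 and compound 3 would stay together across a full concentration range in this assay.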